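This account rests on a few compounds, and the source may have more. Where it says the series, first, only, none or still open, it means among the compounds named here.

Measured compounds:
Compound 1, `COc1ccc(CS(=O)(=O)/C=C/c2ccc(F)cc2)cc1`: 2500 nM
Compound 2, `COc1ccc(CS(=O)(=O)/C=C/c2ccc(F)cc2OC)cc1`: 20000 nM
Compound 3, `COc1ccc(CS(=O)(=O)/C=C/c2cc(OC)ccc2OC)cc1`: a limit only, > 20000 nM

In a functional assay on H157 cells (Homo sapiens) for antiproliferative activity, read by trypan blue exclusion (a higher number here means a weaker inhibitor, a lower number a stronger inhibitor), compound 1 gives 2500 nM and compound 2 gives 20000 nM. For compound 3 the result is only a limit, > 20000 nM. The change methoxy in place of hydrogen on an aromatic carbon produced an 8.0-fold higher number from compound 1 to compound 2 (0.90 log units; beyond the scatter). How the core of compound 1 and the core of compound 3 differ is not broken down here. Compound 4, `COc1ccc(CS(=O)(=O)/C=C/c2cc(OC)c(OC)cc2OC)cc1`, arises from compound 3 by methoxy in place of hydrogen on an aromatic carbon; this is the same kind of change as before, but the surroundings differ: earlier the new group stood ortho to a large group and meta to a fluoro group, now it stands ortho to a methoxy group, meta to a methoxy group and para to a large group. Since compound 3 already sits at the limit of > 20000 nM in this assay, at which 1 of the 3 values shown sits, and the earlier step of an 8.0-fold higher number from compound 1 to compound 2 (0.90 log units; beyond the scatter) weakened inhibition, compound 4 is expected at a step that the limit leaves unreadable from compound 3 to compound 4. Compound 4 is thus estimated at 40000 nM, most likely again reported only as a limit.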

Compound 4, half-maximal inhibitory concentration: > 20000 nM
Compound 4 was reported as a limit; the forecaster's own chance of this, stated with the estimate: 85%; the middle value does not contradict the limit.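

For the compounds shown here, compound 3 and compound 4 are both reported only as limits, and no step between them can be read. The compounds shown leave open whether the added methoxy of compound 4 changes inhibition at all, in either direction.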